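Swapping the heteroaryl ether in a weakly active series

The compounds below may be only part of what the source reports. "The series", "measured", "known", "first", "only" and "open" are said of these compounds alone.

Compound 3 `CC(C)[C@H](NC(=O)COc1cccc2ccccc12)C(=O)N[C@@H](CC(=O)O)C(=O)COc1cc(C(F)(F)F)ncn1` is one of three close analogues tested in a functional assay on Jurkat cells (Homo sapiens) for inhibition; on this read-out lower numbers stand for stronger inhibition and higher numbers for weaker inhibition. In this assay compound 3 gives only a limit, > 200000 nM. Compound 2 `CC(C)[C@H](NC(=O)COc1cccc2ccccc12)C(=O)N[C@@H](CC(=O)O)C(=O)COc1ccccn1` likewise gives only a limit in this assay, > 200000 nM. Compound 1 `Cc1nnc(SCC(=O)[C@H](CC(=O)O)NC(=O)[C@@H](NC(=O)COc2cccc3ccccc23)C(C)C)s1`, which carries the (5-methyl-1,3,4-thiadiazol-2-yl)sulfanyl group instead of an aryl ether, gives 190000 nM in this assay. The recorded steps are an at least 1.0-fold higher number from compound 1 to compound 2 (0.02 log units; that floor lies within the scatter) and an at least 1.0-fold higher number from compound 1 to compound 3 (0.02 log units; that floor lies within the scatter), while the comparison of the two ethers is a step that the two limits leave unreadable from compound 2 to compound 3. Two of the three values therefore sit at the limit of > 200000 nM in this assay, at which 2 of the 3 values shown sit, and none of the steps seen so far can be read as beyond the scatter.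

Compound 4 `CC(C)[C@H](NC(=O)COc1cccc2ccccc12)C(=O)N[C@@H](CC(=O)O)C(=O)COc1ccc2ccccc2n1` differs from compound 3 by quinolin-2-yl in place of 6-(trifluoromethyl)pyrimidin-4-yl on an oxygen on a saturated carbon. For the measured compounds named here, the only measured step at the same place is a step that the two limits leave unreadable from compound 2 to compound 3, which the two limits leave unreadable, and the steps out of compound 1 show only that the ethers are not stronger than the thiadiazolyl sulfide. With nothing pointing in either direction, the change is expected to amount to a number no higher from compound 3 to compound 4 (the limit leaves the size open), that is, no step beyond the scatter. Compound 4 is accordingly estimated at 200000 nM in this assay, with a range from 50000 nM to 600000 nM, and most probably it will again be reported only as a limit.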

Compound 4, half-maximal inhibitory concentration: > 200000 nM
Compound 4: a limit, no number; the forecaster's own chance of this, stated with the estimate: 70%; the middle value sits exactly at the limit.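

In this assay compound 4 is again only a limit, > 200000 nM. Placing quinolin-2-yl, with its aromatic ring of carbon only alongside the ring that holds nitrogen, on this oxygen leaves the series where the single-ring ethers stood, so three different aryl ethers now share the same result: the limit of > 200000 nM in this assay, at which 3 of the 4 values shown sit. The steps that link compound 4 to the other two ethers cannot be read, and the only readable step is an at least 1.0-fold higher number from compound 1 to compound 4 (0.02 log units; that floor lies within the scatter), so this ether cannot be told apart from the thiadiazolyl sulfide.

Going by these compounds, how far the three ethers lie beyond the limit, and whether they differ from one another at all, stays open. On these data alone, it is also open whether another group at this place, such as a plain phenyl ether or an amine in place of the ether oxygen, would bring the read-out down to a measurable number.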